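Ureido Side Chain on a Pyrazolopyrimidine Antiproliferative Series

The source may report more compounds than this note shows. Statements on the series, on what has been measured and on what is new or still open speak of the compounds shown alone.

Going by the values given here, compound 1 `CC(C)c1n[nH]c2c(NCc3ccc(-c4ccccn4)cc3)nc(SCC(O)C(F)(F)F)nc12` gives 690 nM in a functional assay on HT cells (Homo sapiens) for antiproliferative activity, read by fluorescence, with a stated time of 72 h (on this read-out lower numbers stand for stronger inhibition of growth and higher numbers for weaker inhibition of growth), the highest of the three numbers measured so far. Compound 2 `CC(C)c1n[nH]c2c(NCc3ccc(-c4ccccn4)cc3)nc(SCCN)nc12` gives 22 nM and compound 3 `CC(C)c1n[nH]c2c(NCc3ccc(-c4ccccn4)cc3)nc(SCCCO)nc12` gives 109 nM in this assay. Compound 4 `CC(C)c1n[nH]c2c(NCc3ccc(-c4ccccn4)cc3)nc(SCCNC(N)=O)nc12` has not yet been measured; it differs from compound 1 as follows: ureidomethyl in place of 2,2,2-trifluoro-1-hydroxyethyl on a saturated chain carbon bound to a sulfur. Among the compounds with values here, two measured steps bear on it: a 31-fold lower number from compound 1 to compound 2 (1.50 log units; beyond the scatter) and a 6.3-fold lower number from compound 1 to compound 3 (0.80 log units; beyond the scatter), both leaving the same group. The related comparison a 5.0-fold higher number from compound 2 to compound 3 (0.70 log units; beyond the scatter) shows that the amino group gave the lower number. The ureidomethyl group, with two hydrogen-bond donors and one acceptor, is expected to give a modest step down, a 6.3-fold lower number from compound 1 to compound 4 (0.80 log units; beyond the scatter). Compound 4 is therefore estimated at 110 nM, within 35 nM to 350 nM.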

Compound 4, concentration for 50% growth inhibition: 240 nM
For compound 4 the middle estimate is 2.2-fold (0.34 log units) below the measured one; measured number inside the range.
By their numbers in this assay, from the lowest: compound 2; then compound 3; then compound 4; then compound 1.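

In this assay, the ureidomethyl group still improves on 2,2,2-trifluoro-1-hydroxyethyl, with a 2.9-fold lower number from compound 1 to compound 4 (0.46 log units; beyond the scatter), but it does less well than the hydroxyl-ended chain, with a 2.2-fold higher number from compound 3 to compound 4 (0.34 log units; beyond the scatter). Putting a carbamoyl on the amine nitrogen costs the most, with an 11-fold higher number from compound 2 to compound 4 (1.04 log units; beyond the scatter), so among these four compounds the free amino end gives the strongest inhibition of growth. No measurement here explains why the free amine does best. As far as these compounds go, whether an N-methyl amine or a three-carbon chain ending in an amine would go lower remains open.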